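Sulfonamide Variants of One Shared Core: Three Limits So Far

This account rests on a few compounds, and the source may have more. Where it says the series, first, only, none or still open, it means among the compounds named here.

Compound 1 `O=S(=O)(Nc1ccc2oc(-c3ccccc3)nc2c1)c1ccc(Cl)c(Cl)c1` — in an assay on cells for inhibition of HSP60/HSP10 (Homo sapiens), with a stated time of 60 min (a lower number here means a stronger inhibitor, a higher number a weaker inhibitor), compound 1 gives > 100000 nM, which is a limit of the assay and not a number.
Compound 2 `O=S(=O)(Nc1ccc2oc(-c3ccccc3)nc2c1)c1ccccc1Cl` — here compound 2 gives > 100000 nM, again a limit of the assay.
Compound 3 `C=Cc1ccc(S(=O)(=O)Nc2ccc3oc(-c4ccccc4)nc3c2)cc1` — here compound 3 gives > 100000 nM, also a limit of the assay.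

Compound 3 therefore stands nowhere distinct among the values shown: each of the three rests at a limit, and the measured steps a step that the two limits leave unreadable from compound 1 to compound 2, a step that the two limits leave unreadable from compound 1 to compound 3 and a step that the two limits leave unreadable from compound 2 to compound 3 cannot be read in size or direction. Among the compounds with values here, the one piece of evidence is the limit of > 100000 nM in this assay, at which 3 of the 3 values shown sit.

Compound 4 `CS(=O)(=O)Nc1ccc2oc(-c3ccccc3)nc2c1` carries a smaller group on the sulfonyl sulfur: methyl in place of 4-vinylphenyl on a sulfonyl sulfur. All three measured steps bear on this one only in that they change the group on that same sulfur, and none of them moved a value off the limit. Within the data shown here, no step in this assay beyond the scatter is therefore expected from compound 3 to compound 4, and the step of a number no higher from compound 3 to compound 4 (the limit leaves the size open) that the estimate implies is essentially none. Compound 4 is expected to give about 100000 nM, within roughly 30000 nM to 300000 nM, most likely again as a limit.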

Compound 4, half-maximal inhibitory concentration: > 100000 nM
Compound 4: no number, only a limit (the forecaster's own chance of this, stated with the estimate: 85%); the middle value lies on the limit itself.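

In this assay compound 4 also rests at a limit, so its steps to compound 1, compound 2 and compound 3 cannot be read in size or direction: the limit of > 100000 nM in this assay, at which 4 of the 4 values shown sit.

The compounds shown leave open how far each lies beyond that limit, and whether any group on the sulfonyl sulfur of the shared core gives a readable number.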